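Para-substituent swap on compound 2: isopropyl to trifluoromethyl

This account rests on a few compounds, and the source may have more. Where it says the series, first, only, none or still open, it means among the compounds named here.

Measured so far in an assay on HepG2 cells for agonist activity at nuclear receptor subfamily 1 group I member 3 (Homo sapiens), read by a luciferase reporter, with a stated time of 23 h; a lower number here means that less compound is needed, a higher number that more compound is needed for the effect:
- compound 1 `Clc1ccc(CO/N=C/c2c(-c3cccc4ccccc34)nc3sccn23)cc1Cl`: 940 nM
- compound 2 `CC(C)c1ccc(-c2nc3sccn3c2/C=N/OCc2ccc(Cl)c(Cl)c2)cc1`: 590 nM
- compound 3 `Clc1ccc(CO/N=C/c2c(-c3ccc4ccccc4c3)nc3occn23)c(Cl)c1`: 1500 nM

Compound 2 carries the lowest of the three numbers in this assay. Its gap to compound 1 is within the scatter (a 1.6-fold lower number from compound 1 to compound 2 (0.20 log units; within the scatter)), so the two cannot be ranked against each other; its gap to compound 3 is beyond the scatter, compound 3 standing at the higher number. For the measured compounds named here, compound 3 also differs from compound 2 in more than one place, so no single step is defined between them.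

Compound 4 `FC(F)(F)c1ccc(-c2nc3sccn3c2/C=N/OCc2ccc(Cl)c(Cl)c2)cc1` differs from compound 2 in one place: trifluoromethyl in place of isopropyl on an aromatic carbon. Going by the values given here, no measured pair in this set changes a substituent on that phenyl ring; the only single-place step available, from compound 1 to compound 2, swaps the whole aromatic group and gives a 1.6-fold lower number from compound 1 to compound 2 (0.20 log units; within the scatter), within the scatter. That step does not bear directly on the trifluoromethyl for isopropyl exchange, and nothing else in the set does. Without a precedent, the expectation is a step in this assay of no size beyond the scatter, a 1.1-fold higher number from compound 2 to compound 4 (0.04 log units; within the scatter), in either direction. For compound 4 in this assay the estimate is therefore 650 nM, with a range from 250 nM to 1700 nM.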

Compound 4, half-maximal effective concentration: 880 nM
Estimate against measurement, compound 4: 1.4-fold (0.13 log units) below, and the stated range covers the measured number.
By their numbers in this assay, from the lowest: compounds 2, 4, 1 and 3 (each within the scatter of the next, the first and the last beyond it).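

In this assay, trifluoromethyl in place of isopropyl on an aromatic carbon gives a 1.5-fold higher number from compound 2 to compound 4 (0.17 log units; within the scatter) and is the first change shown to a substituent on this phenyl ring, so this pair does not separate the two groups. The exchange of naphthalen-1-yl for 4-(trifluoromethyl)phenyl gives a 1.1-fold lower number from compound 1 to compound 4 (0.03 log units; within the scatter) and, read with a 1.6-fold lower number from compound 1 to compound 2 (0.20 log units; within the scatter) for the exchange to 4-isopropylphenyl, shows three aromatic groups at this place on the shared core with no listed step beyond the scatter. No measurement of any other property accompanies these steps, so nothing here accounts for them.

Going by these compounds, whether another kind of substituent at this place on the phenyl ring, such as an amine, a carboxylic acid or a longer alkyl chain, would give a step beyond the scatter remains open. The trifluoromethyl for isopropyl exchange is also shown on the core of compound 2 alone, so its outcome on the core of compound 3 remains open too.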